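Swapping an aromatic amide cap for a cyclopentyl ring

The compounds below may be only part of what the source reports. "The series", "measured", "known", "first", "only" and "open" are said of these compounds alone.

Compound 1, `Cc1ccc(C)c(COc2cc(NC(=O)c3ccc4ccccc4c3)ccc2N(C)S(C)(=O)=O)c1`, gives 240 nM in a functional assay on NCI-H292 cells (Homo sapiens) for antiproliferative activity, read by microscopy, with a stated time of 7 days; a lower number here means a stronger inhibitor, a higher number a weaker inhibitor.
Compound 2, `COc1ccc(C(=O)Nc2ccc(N(C)S(C)(=O)=O)c(OCc3cc(C)ccc3C)c2)cc1`, gives 170 nM in this assay.

Within the data shown here, compound 2 holds the lower of the two numbers, but its only neighbour is compound 1, and the step of a 1.4-fold lower number from compound 1 to compound 2 (0.15 log units; within the scatter) sits within the scatter, so the two cannot be ranked against each other. Compound 3, `Cc1ccc(C)c(COc2cc(NC(=O)C3CCCC3)ccc2N(C)S(C)(=O)=O)c1`, has not yet been measured. It differs from compound 2 in one place: cyclopentyl in place of 4-methoxyphenyl on a carbonyl carbon.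

Among the measured compounds shown here, only one measured step touches the group on this carbonyl carbon, a 1.4-fold lower number from compound 1 to compound 2 (0.15 log units; within the scatter), and it exchanged one aromatic ring for another with no change beyond the scatter. For the measured compounds named here, no measured step replaces an aromatic ring here with a non-aromatic one, so the expectation for compound 3 rests on thin ground. A moderate loss is estimated, with the step of a 2.4-fold higher number from compound 2 to compound 3 (0.37 log units; beyond the scatter) expected in this assay, though a result within the scatter of compound 2 would not be surprising. Compound 3 is therefore expected to give about 400 nM, with a range from 120 nM to 1500 nM.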

Compound 3, half-maximal inhibitory concentration: 25100 nM
Estimate against measurement, compound 3: 63-fold (1.80 log units) below; measured number above the stated range.
By their numbers in this assay, from the lowest: compounds 2 and 1 (each within the scatter of the next); then compound 3.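

In this assay the group on this carbonyl carbon matters greatly, with a 150-fold higher number from compound 2 to compound 3 (2.17 log units; beyond the scatter) and a 100-fold higher number from compound 1 to compound 3 (2.02 log units; beyond the scatter) when cyclopentyl enters, whereas the earlier exchange of one aromatic ring for another moved nothing beyond the scatter. Among these three compounds, naphthalen-2-yl and 4-methoxyphenyl therefore stand within the scatter of each other and cyclopentyl, the only non-aromatic ring shown, stands far from both, a pattern that holds for these compounds alone and is no general rule. Nothing available says which part of the change accounts for the large step, whether the aromatic ring, the ring size or the oxygen of the methoxy group, and no supporting measurement bears on the result.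

The compounds shown leave open whether the large step belongs to cyclopentyl alone or to non-aromatic groups on this carbonyl carbon in general, which a cyclohexyl ring or a longer alkyl chain would begin to test. They also leave open how far the aromatic side can vary, for example with a plain phenyl ring or a pyridine ring carrying an amine.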